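Series notes: side-chain variation on a shared aminopyrimidine-free core

The compounds below may be only part of what the source reports. "The series", "measured", "known", "first", "only" and "open" are said of these compounds alone.

Measured compounds:
- compound 1, `CCCCNc1nc(N)nc(C)c1CCc1ccccc1`: 1190 nM
- compound 2, `CCCCNc1nc(N)nc(C)c1CCCn1ccc2ccccc21`: 1100 nM

In an assay on HEK293 cells for agonist activity at Toll-like receptor 8 (Homo sapiens), read by spectrophotometry (on this read-out higher numbers stand for an effect only at larger amounts of compound and lower numbers for an effect already at smaller amounts), compound 1 gives 1190 nM and compound 2 gives 1100 nM. The two numbers lie within the scatter of each other, so compound 1 cannot be separated from compound 2 on this read-out; it is simply one of two compounds giving numbers of the same size. For the measured compounds named here, no measured pair differs in one place, so no computed step is available.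

Compound 3, `CCCCCc1c(C)nc(N)nc1NCCCC`, differs from compound 1 by the change (propyl in place of phenyl on a saturated chain carbon, two bonds along the chain from an aromatic carbon). Cut one bond further out, the same difference reads benzyl to butyl. Going by the values given here, with no step of this kind measured, the expectation is a modest rise in this assay, on the order of the scatter or a little beyond it, rather than a large change in either direction. For compound 3 the estimated value in this assay is 2200 nM, with a range from 700 nM to 7000 nM, which corresponds to an expected step of a 1.8-fold higher number from compound 1 to compound 3 (0.27 log units; within the scatter).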

Compound 3, half-maximal effective concentration: 1220 nM
For compound 3 the middle estimate is 1.8-fold (0.26 log units) above the measured one; the measured number falls inside the stated range.
By their numbers in this assay, from the lowest: compounds 2, 1 and 3 (each within the scatter of the next).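

Going from phenyl to propyl on a saturated chain carbon, two bonds along the chain from an aromatic carbon, gives a 1.0-fold higher number from compound 1 to compound 3 (0.01 log units; within the scatter) in this assay. At this place, then, an aromatic ring is not needed for a number of this size: propyl, with no ring and fewer heavy atoms than phenyl, cannot be told apart from phenyl on this read-out. Nothing at hand accounts for this result.

Still open, going by these compounds, is whether the flat response extends beyond these two groups, since a longer chain such as octyl, an amine or a carboxylic acid at the same place could still give a step beyond the scatter. Also open, on these data alone, is whether phenyl and propyl would stay this close with a different chain on the shared core.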